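The compounds below may be only part of what the source reports. "The series", "measured", "known", "first", "only" and "open" are said of these compounds alone.

Measured compounds:
compound 1, `NC1=NC2(CCSCC2)N(OCCCOc2ccc(Cl)c(Cl)c2)C(N)=N1`: 1 nM
compound 2, `NC1=NC2(CCOCC2)N(OCCCOc2ccc(Cl)cc2Cl)C(N)=N1`: 70 nM
compound 3, `NC1=NC2(CCOCC2)N(OCCCOc2cc(Cl)c(Cl)cc2Cl)C(N)=N1`: 680 nM

In a functional assay on A549 cells (Homo sapiens) for antiproliferative activity, read by MTT assay, with a stated time of 72 h (on this read-out higher numbers stand for weaker inhibition and lower numbers for stronger inhibition), compound 1 gives the lowest of the three numbers; compound 2 stands well above it and compound 3 furthest away, both gaps beyond the scatter. Compounds 2 and 3 share a core that differs from that of compound 1, so neither gap is a single-point comparison.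

Compound 4, `NC1=NC2(CCSCC2)N(OCCCOc2ccc(Cl)cc2)C(N)=N1`, has not been measured. It differs from compound 1 in one place: hydrogen in place of chloro on an aromatic carbon.

Going by the values given here, only one measured step touches a chloro on the aromatic ring: a 9.7-fold higher number from compound 2 to compound 3 (0.99 log units; beyond the scatter), where a chloro enters. Its direction, read backwards, would suggest that losing a chloro is not harmful, but the chloro in that step enters at a different place and on a different core, so it carries only loosely. The change from compound 1 to compound 4 removes a substituent from the most potent compound in the set, and the number for compound 1 leaves little room for improvement. On balance a modest loss is expected, a 3.0-fold higher number from compound 1 to compound 4 (0.48 log units; beyond the scatter), with a wide band.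

Compound 4 is therefore estimated at 3 nM, within 0.5 nM to 20 nM.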

Compound 4, half-maximal inhibitory concentration: 580 nM
The estimate for compound 4 lay 190-fold (2.29 log units) below the measured number; measured number outside the range, above it.
By their numbers in this assay, from the lowest: compound 1; then compound 2; then compounds 4 and 3 (each within the scatter of the next).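

In this assay, the change from 3,4-dichlorophenyl to 4-chlorophenyl gives a 580-fold higher number from compound 1 to compound 4 (2.76 log units; beyond the scatter), so on the core of compound 1 the low number depends heavily on the chloro at this aromatic carbon, ortho to a chloro group. Only one heavy atom leaves in this large step, and no hydrogen-bond donor, hydrogen-bond acceptor or net charge is involved. The earlier compounds showed a chloro entering the aromatic ring only as a loss, and the new pair shows that this change has no single direction in the series: the same change on two cores in this assay, a 9.7-fold higher number (0.99 log units; beyond the scatter) from compound 2 to compound 3 and a 580-fold lower number (2.76 log units; beyond the scatter) from compound 4 to compound 1, 5600-fold (3.75 log units) apart, beyond the scatter of two such steps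

The compounds shown hold no pair with the same aromatic ring on both cores, which leaves open how much of this reversal belongs to the core and how much to the chlorine pattern on the ring. Also open, going by these compounds, is whether a methyl, a bromo or a methoxy group at this aromatic carbon would keep a number near that of compound 1, 1 nM, or whether the activity is specific to chloro.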